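Aryl regioisomer step from compound 3 to compound 4

The source may report more compounds than this note shows. Statements on the series, on what has been measured and on what is new or still open speak of the compounds shown alone.

Compound 1, `COC(=O)c1cc(OCCCCOc2ccc(C(=O)CC(C)(C)C)c(O)c2C)ccc1F`, gives "not active" (no number reported) in an assay for positive allosteric modulation of metabotropic glutamate receptor 3 (Rattus norvegicus); on this read-out lower numbers stand for an effect already at smaller amounts and higher numbers for an effect only at larger amounts of compound. Compound 2, `Cc1c(OC[C@H](C)COc2ccc(F)c(C(=O)O)c2)ccc(C(=O)CC(C)(C)C)c1O`, gives 651 nM in this assay. Compound 3, `Cc1c(OC[C@@H](C)COc2ccc(F)c(C(=O)O)c2)ccc(C(=O)CC(C)(C)C)c1O`, gives 1180 nM in this assay.

Compound 3 stands at the highest of the two numbers shown, with compound 2 as its nearest neighbour; the step of a 1.8-fold higher number from compound 2 to compound 3 (0.26 log units; within the scatter), the two differing only in configuration as drawn (the fact that compounds 2 and 3 differ only in the configuration as drawn), lies within the scatter. Compound 1 carries an ester in place of the acid and is without a number.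

Compound 4, `Cc1c(OC[C@@H](C)COc2cc(C(=O)O)ccc2F)ccc(C(=O)CC(C)(C)C)c1O`, differs from compound 3 by 5-carboxy-2-fluorophenyl in place of 3-carboxy-4-fluorophenyl on an oxygen on a saturated carbon. Within the data shown here, no measured step concerns such a rearrangement of the aryl substituents; the only measured step, between compound 2 and compound 3, changes configuration alone and stays within the scatter, so it gives no direction for compound 4. The acid is kept, which is shared by the two compounds with numbers, while compound 1 with an ester gives none. The expectation for compound 4 is therefore a loss without strong grounds, the step of a 2.1-fold higher number from compound 3 to compound 4 (0.33 log units; beyond the scatter) being an estimate. For compound 4 a value of 2500 nM is expected, between 600 nM and 10000 nM.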

Compound 4, half-maximal effective concentration: 3950 nM
The estimate for compound 4 lay 1.6-fold (0.20 log units) below the measured number; low and high end bracket the measured number.
By their numbers in this assay, from the lowest: compounds 2 and 3 (each within the scatter of the next); then compound 4.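

In this assay, the arrangement of the two substituents on the aryl group proves to matter at this position, where it sits on an oxygen on a saturated carbon: a 3.3-fold higher number from compound 3 to compound 4 (0.52 log units; beyond the scatter), with 5-carboxy-2-fluorophenyl in place of 3-carboxy-4-fluorophenyl. This modest change is the only one shown that lies beyond the scatter, whereas the change of configuration alone, a 1.8-fold higher number from compound 2 to compound 3 (0.26 log units; within the scatter), stays within it, so with the same atoms joined differently, the rearrangement counts for more here than the drawn stereocentre. Nothing at hand on these compounds bears on the reason for the step.

On these data alone, the series shows this rearrangement only in the configuration of compound 3, so its size in the configuration of compound 2 remains open. Also open, as far as these compounds go, is how this position would respond to a chlorine or a methyl group in place of the fluorine, or to a tetrazole in place of the carboxylic acid.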